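Extending a chain from methyl to propyl

The source may hold more compounds than are shown below. What is called first, only, known or untested is meant among the compounds shown, and "the series" means these compounds.

Measured compounds:
compound 1 `CCCc1ccc(-c2cc(Cl)cc(C(=O)Nc3nn[nH]n3)n2)cc1`: 78%
compound 2 `COc1cc(C(=O)Nc2nn[nH]n2)nc(-c2ccc(C)cc2)c1`: 42%

Of the compounds shown here, two have been tested in a functional assay on the whole organism with Rattus norvegicus as the target, at a dose of 1 mg/kg by the oral route; a lower number here means a weaker effect, a higher number a stronger effect of the compound at the dose given. Compound 1 gives 78%, while compound 2 gives 42%. Compound 2 thus stands lowest of the two numbers, and the gap to compound 1 lies beyond the scatter. Among the measured compounds shown here, the two compounds differ in more than one place, so no single step between them is counted.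

Compound 3 `CCCc1ccc(-c2cc(OC)cc(C(=O)Nc3nn[nH]n3)n2)cc1` has not yet been measured in this assay. It differs from compound 2 by ethyl in place of hydrogen on a saturated chain carbon bound to an aromatic carbon. Compound 3 therefore carries the same propyl chain as compound 1, but keeps the remaining substitution of compound 2.

Because compound 1 with its propyl chain gives 78%, the step from compound 2 to compound 3 is expected to be an increase beyond the scatter, estimated at a number 18 percentage points higher from compound 2 to compound 3 (beyond the scatter). Compound 3 is expected to give 60%, with a range from 40% to 78%.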

Compound 3, a percentage reported as inhibition, in the whole organism at one dose (the size of the read-out at that dose, not a potency): 73%
For compound 3 the middle estimate is 13 percentage points below the measured one, and the stated range covers the measured number.
By their numbers in this assay, from the lowest: compound 2; then compounds 3 and 1 (each within the scatter of the next).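

In this assay, the change from methyl to propyl gives a number 31 percentage points higher from compound 2 to compound 3 (beyond the scatter), so with the rest of the structure held constant, this one change on a saturated chain carbon bound to an aromatic carbon produces a large step, something the earlier pair, which differed in more than one place, could not show. With the propyl chain kept, methoxy in place of chloro on an aromatic carbon gives a number 5 percentage points lower from compound 1 to compound 3 (within the scatter), so at this dose the two groups cannot be told apart in this assay. Nothing measured here explains either step.

The compounds shown leave open whether a longer chain such as butyl, or a propyl chain ending in an amine or a carboxylic acid, would keep this effect. They also leave open how the two steps would read at other doses.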